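Naphthalenyl for cyanobenzyl: a step repeated on a second core

A few compounds are considered here, and "the series" means these few. Any claim that something is new, unique, unknown or untested is made for them only; others in the source may bear on it.

Measured compounds:
Compound 1 `COc1ccc(F)cc1CNCCCNc1ccnc2cc(Cc3ccc(C#N)cc3)ccc12`: 6050 nM
Compound 2 `COc1ccc(F)cc1CNCCCNc1ccnc2cc(-c3cccc4ccccc34)ccc12`: 16000 nM
Compound 3 `N#Cc1ccc(Cc2ccc3c(NCCCNCc4ccco4)ccnc3c2)cc1`: 7910 nM

In an ADME assay on HepG2 cells (Homo sapiens) for cytotoxicity, read by luminescence, CellTiter-Glo and ATP content, with a stated time of 72 h (a lower number here means that less compound is needed, a higher number that more compound is needed for the effect), compound 1 gives 6050 nM. Compound 2 differs from it in one place, (naphthalen-1-yl in place of 4-cyanobenzyl on an aromatic carbon), and this brought a 2.6-fold higher number from compound 1 to compound 2 (0.42 log units; beyond the scatter), so more of compound 2 was needed to harm the cells. Compound 3 shares the left-hand part of compound 1 but carries a different amine substituent; the two cores differ as furan-2-yl in place of 5-fluoro-2-methoxyphenyl on a saturated chain carbon bound to an amine nitrogen, and in this assay the step was a 1.3-fold higher number from compound 1 to compound 3 (0.12 log units; within the scatter), which is not a change the measurement can tell apart.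

Compound 4 `c1coc(CNCCCNc2ccnc3cc(-c4cccc5ccccc45)ccc23)c1` has not yet been measured. It differs from compound 3 as naphthalen-1-yl in place of 4-cyanobenzyl on an aromatic carbon, at the same position as the change from compound 1 to compound 2, so it is the same change on a second core. Because that first step gave a 2.6-fold higher number from compound 1 to compound 2 (0.42 log units; beyond the scatter), a step of similar size is expected from compound 3 to compound 4, namely a 2.5-fold higher number from compound 3 to compound 4 (0.40 log units; beyond the scatter). Starting from compound 3 at 7910 nM, compound 4 is therefore estimated at 20000 nM, with a likely range from 9000 nM to 45000 nM; this rests on one prior example only.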

Compound 4, half-maximal effective concentration: 5600 nM
The estimate for compound 4 lay 3.6-fold (0.55 log units) above the measured number, outside the stated range (below it).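

On the core of compound 3, naphthalen-1-yl in place of 4-cyanobenzyl gave a 1.4-fold lower number from compound 3 to compound 4 (0.15 log units; within the scatter), so in this assay the rise seen on the core of compound 1 did not carry over: the same change on two cores in this assay, a 2.6-fold higher number (0.42 log units; beyond the scatter) from compound 1 to compound 2 and a 1.4-fold lower number (0.15 log units; within the scatter) from compound 3 to compound 4, 3.7-fold (0.57 log units) apart, beyond the scatter of two such steps

The other change in these four compounds tells the same story, since furan-2-yl in place of 5-fluoro-2-methoxyphenyl gave a 2.9-fold lower number from compound 2 to compound 4 (0.46 log units; beyond the scatter), whereas on the core of compound 1 it gave a step within the scatter: the same change on two cores in this assay, a 1.3-fold higher number (0.12 log units; within the scatter) from compound 1 to compound 3 and a 2.9-fold lower number (0.46 log units; beyond the scatter) from compound 2 to compound 4, 3.7-fold (0.57 log units) apart, beyond the scatter of two such steps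

Together these show that, among these compounds, the effect of each change depends on the group at the other site, but both comparisons come from the same four compounds, so this is one observation seen from two sides and it does not show why the steps differ.

As far as these compounds go, it remains open whether the same dependence would appear with a plain benzyl group on that aromatic carbon or a thiophene ring in place of the furan-2-yl. From the compounds shown here alone, a longer chain linking the two amine nitrogens is equally open.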